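Plasma stability notes: methyl in place of methoxy

The compounds below may be only part of what the source reports. "The series", "measured", "known", "first", "only" and "open" are said of these compounds alone.

Three analogues of the shared core share a four-carbon chain ending in a phenyl ring and differ only in the fused bicyclic carrying the urea. Compound 1 `O=C(NCCCCc1ccccc1)n1nnc2ncccc21` is read in an ADME assay on a cell-free system (plasma, Mus musculus) for metabolic stability, read by HPLC, with a stated time of 120 min, tested at 2 uM; on this read-out lower numbers stand for a shorter-lived compound and higher numbers for a longer-lived compound. Compound 1 gives < 0.0834 h, which is a limit of this assay rather than a number (the limit of < 0.0834 h in this assay, at which 1 of the 3 values shown sits). Compound 2 `O=C(NCCCCc1ccccc1)n1ncc2ccccc21` gives > 2 h in this assay, again a limit and not a number. Compound 3 `COc1nc2ccccc2n1C(=O)NCCCCc1ccccc1` gives > 2 h in this assay, also a limit (the limit of > 2 h in this assay, at which 2 of the 3 values shown sit). Compound 3 therefore stands at the long-lived end of what is recorded for the series, where compound 2 also sits, while compound 1 sits at the short-lived end.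

Compound 4 `Cc1nc2ccccc2n1C(=O)NCCCCc1ccccc1` is not yet measured in this assay. It differs from compound 3 in one place (methyl in place of methoxy on an aromatic carbon).

For the measured compounds named here, no step between measured compounds is recorded, so the size of this change cannot be calibrated from the series. The expectation is no step beyond the usual scatter, and compound 4 is estimated at 2.5 h in this assay, within 1 h to 6 h, which is an expected step that the limit leaves unreadable from compound 3 to compound 4 from compound 3. A fresh reading of compound 4 in this assay will show whether it stays at the stable end or moves.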

Compound 4, half-life: 0.183 h
The estimate for compound 4 lay 14-fold (1.14 log units) above the measured number, outside the stated range (below it).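

In this assay, methyl in place of methoxy gives an at least 10-fold lower number from compound 3 to compound 4 (1.03 log units; beyond the scatter), so this aromatic carbon, between two ring nitrogen atoms and next to the ring atom that bears a large group, is a place where a single small change separates two clearly different half-lives. For the compounds shown here, the earlier compounds offered no step in one place, and compound 4, at 0.183 h, is the first of this pair to give a number rather than a limit. The half-life of compound 3 is a limit, so the true size of the step remains unfixed and the printed step gives only its smallest size: the limit of > 2 h in this assay, at which 2 of the 4 values shown sit.

This one pair cannot separate what the methyl brings from what the departing methoxy takes away, and nothing shown gives a cause for the step. From the compounds shown here alone, whether an ethoxy group, a chlorine atom or an amine on this carbon would keep a half-life like that of compound 3 or fall towards that of compound 4 stays open, as does whether the same change would have a similar effect with a shorter chain in place of the four-carbon chain.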